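Swapping the Hydroxylated Ring on the Amide Nitrogen

A few compounds are considered here, and "the series" means these few. Any claim that something is new, unique, unknown or untested is made for them only; others in the source may bear on it.

Compound 1, `CN(C)C(=O)CNC(=O)c1cn(Cc2ccc(-n3cccn3)cc2)c2cccnc12`, gives 9.3 mL/min/kg in an ADME assay on liver for metabolic stability, with Liver microsome (Homo sapiens) as the target, using microsomes; on this read-out lower numbers stand for slow clearance and higher numbers for fast clearance.
Compound 2, `O=C(N[C@H]1CCCC[C@@H]1O)c1cn(Cc2ccc(-n3cccn3)cc2)c2cccnc12`, gives 59 mL/min/kg.
Compound 3, `Cn1ccc(-c2ccc(Cn3cc(C(=O)N[C@H]4CCCC[C@@H]4O)c4ncccc43)cc2)n1`, gives 47 mL/min/kg.

Compound 2 has the highest number of the three, meaning the fastest clearance seen so far. Compound 3 is nearest to it: a 1.3-fold lower number from compound 2 to compound 3 (0.10 log units; within the scatter), so the two cannot be told apart. Compound 1 is furthest away: a 6.3-fold higher number from compound 1 to compound 2 (0.80 log units; beyond the scatter), a real gap.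

The next compound, compound 4, `O=C(NCC1(O)CCC1)c1cn(Cc2ccc(-n3cccn3)cc2)c2cccnc12`, differs from compound 2 in one place: (1-hydroxycyclobutyl)methyl in place of 2-hydroxycyclohexyl on an amide-type nitrogen. Going by the values given here, no measured step exchanges one hydroxylated ring for another at this nitrogen, so there is no direct precedent. Among the compounds with values here, the only step at this position is a 6.3-fold higher number from compound 1 to compound 2 (0.80 log units; beyond the scatter), which shows that the group on the amide nitrogen can shift the read-out well beyond the scatter. With no closer guide, a moderate fall is expected, a 1.7-fold lower number from compound 2 to compound 4 (0.23 log units; within the scatter), carrying wide uncertainty. Compound 4 is therefore estimated at 35 mL/min/kg, in a range from 15 mL/min/kg to 75 mL/min/kg.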

Compound 4, clearance: 17 mL/min/kg
Compound 4: the middle estimate sits 2.1-fold (0.31 log units) above what was measured, and the stated range covers the measured number.
By their numbers in this assay, from the lowest: compounds 1 and 4 (each within the scatter of the next); then compounds 3 and 2 (each within the scatter of the next).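

In this assay, changing one hydroxylated ring group for another on the amide nitrogen moves the read-out beyond the scatter (a 3.5-fold lower number from compound 2 to compound 4 (0.54 log units; beyond the scatter)), so having a hydroxyl and a ring on this nitrogen does not by itself fix the number. The step from dimethylcarbamoyl to 1-hydroxycyclobutyl on the chain carbon (a 1.8-fold higher number from compound 1 to compound 4 (0.26 log units; within the scatter)) lies within the scatter, so a hydroxylated ring here need not come with fast clearance. No measurement given here explains why the two ring groups differ.

The step changes ring size and removes the stereocentres together, leaving their separate contributions open. A cyclobutylmethyl group without the hydroxyl, or an amine on the same chain, would show whether the hydroxyl matters, and pairing (1-hydroxycyclobutyl)methyl with 1-methyl-1H-pyrazol-3-yl would test whether the two changes combine.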